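This account rests on a few compounds, and the source may have more. Where it says the series, first, only, none or still open, it means among the compounds named here.

Measured so far:
compound 1, `NNc1nonc1/C(=N/O)Nc1ccc(F)c(Br)c1` — 556 nM
compound 2, `NNS(=O)(=O)CCNc1nonc1/C(=N/O)Nc1ccc(F)c(Br)c1` — > 800 nM

In an assay on HeLa cells for inhibition of Indoleamine 2,3-dioxygenase 1 (Homo sapiens), read by spectrophotometry, with a stated time of 24 h (a lower number here means that less compound is needed, a higher number that more compound is needed for the effect), compound 1 gives 556 nM. Compound 2, `NNS(=O)(=O)CCNc1nonc1/C(=N/O)Nc1ccc(F)c(Br)c1`, reaches only the limit of this assay, > 800 nM, so no number stands for it. Within the data shown here, the one measured step, an at least 1.4-fold higher number from compound 1 to compound 2 (0.15 log units; that floor lies within the scatter), is therefore only a floor, and the limit of > 800 nM in this assay, at which 1 of the 2 values shown sits, shows where compound 2 sits.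

Compound 3, `NS(=O)(=O)CCONc1nonc1/C(=N/O)Nc1ccc(F)c(Br)c1`, is not yet measured. It differs from compound 2 by 2-sulfamoylethoxy in place of 2-(aminosulfamoyl)ethyl on a nitrogen on an aromatic ring. No measured step covers this exchange; the only step shown, from compound 1 to compound 2, concerns a different substituent on the same nitrogen, and its floor lies within the scatter. With compound 2 at the limit, the expectation for compound 3 in this assay is a value near that limit, with the step that the limit leaves unreadable from compound 2 to compound 3 expected to stay within the scatter and a fair chance that the expected outcome is once more only a limit rather than a number. Compound 3 is estimated at 1200 nM, with a range from 450 nM to 3200 nM.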

Compound 3, half-maximal effective concentration: 27 nM
For compound 3 the middle estimate is 44-fold (1.65 log units) above the measured one; measured number outside the range, below it.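

At this place, on a nitrogen on an aromatic ring, the exchange of 2-(aminosulfamoyl)ethyl for 2-sulfamoylethoxy, two chains equal in heavy-atom count, gives in this assay an at least 29-fold lower number from compound 2 to compound 3 (1.47 log units; beyond the scatter). That step is only a floor, since compound 2 stands at a limit of the assay and not at a number: the limit of > 800 nM in this assay, at which 1 of the 3 values shown sits.
Against the amino group, the same chain gives a 21-fold lower number from compound 1 to compound 3 (1.31 log units; beyond the scatter), so this nitrogen can carry a substituent with a change beyond the scatter, which the earlier pair, with its floor inside the scatter, did not show.

The two chains differ both in the oxygen of the ethoxy link and at the sulfamoyl end, and the compounds shown do not separate these two differences or give a reason for the size of the step. Also open, on these data alone, is whether a longer chain, or a carboxylic acid in place of the sulfamoyl end, would keep the number of compound 3, 27 nM.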